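The source may report more compounds than this note shows. Statements on the series, on what has been measured and on what is new or still open speak of the compounds shown alone.

Three compounds share one core and differ only in the group attached to a saturated ring carbon. In a functional assay on MT4 cells (Homo sapiens) for cytotoxicity (a lower number here means that less compound is tolerated, a higher number that more compound is tolerated), compound 1 `CCc1c[nH]c(=O)n([C@@H]2O[C@H](CO[Si](C)(C)C(C)(C)C)[C@@]3(OS(=O)(=O)C=C3N)[C@H]2O[Si](C)(C)C(C)(C)C)c1=O` gives 5500 nM. Compound 2 `CCn1c(=O)c(C)cn([C@@H]2O[C@H](CO[Si](C)(C)C(C)(C)C)[C@@]3(OS(=O)(=O)C=C3N)[C@H]2O[Si](C)(C)C(C)(C)C)c1=O` gives 123000 nM, a step of a 22-fold higher number from compound 1 to compound 2 (1.35 log units; beyond the scatter). Compound 3 `C=CCn1c(=O)c(C)cn([C@@H]2O[C@H](CO[Si](C)(C)C(C)(C)C)[C@@]3(OS(=O)(=O)C=C3N)[C@H]2O[Si](C)(C)C(C)(C)C)c1=O` reaches only a limit of this assay, > 360000 nM. Compound 3 thus stands at the limit (the limit of > 360000 nM in this assay, at which 1 of the 3 values shown sits). The change from compound 1 gave an at least 65-fold higher number from compound 1 to compound 3 (1.81 log units; beyond the scatter), and the change at the chain carbon gave an at least 2.9-fold higher number from compound 2 to compound 3 (0.46 log units; beyond the scatter). Compound 4 `CC(C)=CCn1c(=O)c(C)cn([C@@H]2O[C@H](CO[Si](C)(C)C(C)(C)C)[C@@]3(OS(=O)(=O)C=C3N)[C@H]2O[Si](C)(C)C(C)(C)C)c1=O` carries 2-methylprop-1-en-1-yl in place of vinyl on a saturated chain carbon bound to an aromatic nitrogen. The step of an at least 2.9-fold higher number from compound 2 to compound 3 (0.46 log units; beyond the scatter) at the same place and the limit already reached by compound 3 suggest another higher number, or none beyond the scatter. Compound 4 is therefore expected to give 500000 nM, with a range from 200000 nM to 1500000 nM. This expected step is a step that the limit leaves unreadable from compound 3 to compound 4, most likely reported again only as a limit.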

Compound 4, half-maximal cytotoxic concentration: 69000 nM
Beside the measured number, compound 4's estimate is 7.2-fold (0.86 log units) above it, outside the stated range (below it).
By their numbers in this assay, from the lowest: compound 1; then compounds 4 and 2 (each within the scatter of the next). At a limit, above all of these: compound 3.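

In this assay, a larger group at this place does not keep raising the tolerated concentration: 3-methylbut-2-en-1-yl in place of allyl gave an at least 5.2-fold lower number from compound 3 to compound 4 (0.71 log units; beyond the scatter). Set against the ethyl chain, the same group gave a 1.8-fold lower number from compound 2 to compound 4 (0.25 log units; within the scatter), so the rise seen with allyl is lost and the two compounds in this step cannot be told apart. The true size of the drop stays unknown because the starting value is only a limit: the limit of > 360000 nM in this assay, at which 1 of the 4 values shown sits.

Going by these compounds, whether the high value belongs to allyl alone remains open. A saturated propyl or butyl chain, or a benzyl group, at this place would test that.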